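Removing the Cyclopropylmethoxy Group from Compound 2

The source may hold more compounds than are shown below. What is called first, only, known or untested is meant among the compounds shown, and "the series" means these compounds.

Of the compounds shown here, two have been measured in a functional assay on PC-12 cells (Rattus norvegicus) for inhibition, read by sulforhodamine B assay; on this read-out higher numbers stand for weaker inhibition and lower numbers for stronger inhibition. Compound 1, `O=C1N=C(O)S/C1=C\c1ccc(OCC2CCCCO2)cc1`, gives 22000 nM in this assay. Compound 2, `O=C1NC(=O)C(Cc2ccc(OCC3CC3)cc2)S1`, shares only part of its shape with compound 1 and is not a single-change neighbour of it, so the two numbers can only be set side by side. Compound 2 sits at the limit of > 100000 nM in this assay, at which 1 of the 2 values shown sits, which is a limit of this assay and not a number. In this assay compound 2 gives > 100000 nM, again a limit rather than a number.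

Compound 3, `O=C1NC(=O)C(Cc2ccccc2)S1`, differs from compound 2 by hydrogen in place of cyclopropylmethoxy on an aromatic carbon. The change strips away the cyclopropylmethoxy and leaves the rest of compound 2 untouched. For the measured compounds named here, no step between compounds differing in one place has been measured here, so the size of this change is open. Given that compound 2 already reads only a limit, the step that the limit leaves unreadable from compound 2 to compound 3 is expected to be none beyond the scatter. Compound 3 is expected to give 150000 nM, within 50000 nM to 500000 nM, most likely reported once more as a limit.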

Compound 3, half-maximal inhibitory concentration: > 100000 nM
Compound 3 gave a limit, no number (the forecaster's own chance of this, stated with the estimate: 80%); the middle value lies beyond the limit too.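

For the compounds shown here, compound 2 and compound 3 both stand at a limit of this assay and not at a number, so no step between them can be read. The compounds shown leave open whether hydrogen in place of cyclopropylmethoxy on the aromatic carbon changes inhibition in this assay at all, and by how much.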